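Chloro in place of methyl: an expected step

A few compounds are considered here, and "the series" means these few. Any claim that something is new, unique, unknown or untested is made for them only; others in the source may bear on it.

Of the compounds shown here, three have been measured in an ADME assay on the whole organism with Oryza sativa as the target, tested at 1 uM; on this read-out lower numbers stand for a stronger effect and higher numbers for a weaker effect at the one concentration tested. Compound 1 `Cc1ccccc1NC(=O)N[C@H](C)c1ccccc1` gives 100%, compound 2 `Cc1ccccc1NC(=O)N[C@@H](C)c1ccccc1` gives 99%, and compound 3 `CCCCCCCc1ccc(NC(=O)N[C@H](C)c2ccccc2)cc1` gives 100%. Compound 2 thus stands among three numbers that all lie within the scatter of one another. For the measured compounds named here, the only step between two compounds that differ in one place is a number 1 percentage points lower from compound 1 to compound 2 (within the scatter), a step that rests on (the fact that compounds 1 and 2 differ only in the configuration as drawn).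

Compound 4 `C[C@H](NC(=O)Nc1ccccc1Cl)c1ccccc1` has not yet been measured. It differs from compound 2 in one place: chloro in place of methyl on an aromatic carbon. Going by the values given here, no measured step involves this exchange. Among the compounds with values here, the single step available, the change of configuration between compound 1 and compound 2, lay within the scatter, and the three numbers in hand give no ground for expecting a move beyond the scatter here. Compound 4 is therefore expected to yield a number in this assay close to that of compound 2, with an expected step of a number 1 percentage points lower from compound 2 to compound 4 (within the scatter). The estimate for compound 4 is 98%, ranging from 85% to 100%.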

Compound 4, a percentage reported as activity, at one concentration (the size of the read-out at that concentration, not a potency): 104%
Estimate against measurement, compound 4: 6 percentage points below, and the stated range ends below it.
By their numbers in this assay, from the lowest: compounds 2, 1, 3 and 4 (each within the scatter of the next).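

In this assay, for the compounds shown here, chloro in place of methyl on an aromatic carbon, ortho to a large group, gives a number 5 percentage points higher from compound 2 to compound 4 (within the scatter) and is the first exchange of a group at this place to be measured. It shows that, at the one concentration tested, this place carries chloro as well as methyl with no move beyond the scatter, so this single exchange does not separate the two groups. Nothing measured here bears on what lies behind this result.

From the compounds shown here alone, it remains open whether a methoxy, an amine or a carboxylic acid on this same aromatic carbon would move the read-out beyond the scatter. Going by these compounds, it is also open whether chloro and methyl would stay within the scatter of each other at any other concentration or on another position of the ring.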